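The source may report more compounds than this note shows. Statements on the series, on what has been measured and on what is new or still open speak of the compounds shown alone.

Measured so far in a physicochemical assay for solubility, with a stated time of 24 h, tested at 30 mg/mL; a lower number here means a less soluble compound, a higher number a more soluble compound:
compound 1 `CC(=O)N1CC(CC(=O)NO)(NS(=O)(=O)c2ccc(Cc3cc(C)nc4ccccc34)cc2)C1`: 1900000 nM
compound 2 `Cc1cc(COc2ccc(S(=O)(=O)NC(C)(C)CC(=O)NO)cc2)c2ccccc2n1`: 1600000 nM
compound 3 `Cc1cc(COc2ccc(S(=O)(=O)NC3(CC(=O)NO)CCN(C(=O)CC(C)C)C3)cc2)c2ccccc2n1`: 17000000 nM; 7900000 nM (2 entries)

Compound 1 and compound 2 lie within the scatter of each other. Compound 3 sits well above both, with its separate entries (the several entries of compound 3 in this assay, 17000000 nM; 7900000 nM (2 entries)).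

Compound 4 `Cc1cc(COc2ccc(S(=O)(=O)NCC(=O)NO)cc2)c2ccccc2n1` departs from compound 2 by one change on a sulfonamide nitrogen: a group of 5 heavy atoms (2 carbon, 1 nitrogen, 2 oxygen; no ring) in place of a group of 8 heavy atoms (5 carbon, 1 nitrogen, 2 oxygen; no ring), on a sulfonamide nitrogen.

Going by the values given here, no measured pair in this assay isolates a change of this kind, so no shift beyond the scatter is expected. The expected move is a 1.1-fold higher number from compound 2 to compound 4 (0.03 log units; within the scatter), and this estimate has little direct support.

Compound 4 is expected at 1700000 nM, with an estimated range of 500000 nM to 6000000 nM.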

Compound 4, solubility: 100000 nM
The estimate for compound 4 lay 17-fold (1.23 log units) above the measured number, and the stated range ends above it.
By their numbers in this assay, from the lowest: compound 4; then compounds 2 and 1 (each within the scatter of the next).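

In this assay, the sulfonamide nitrogen proves a position where a single change moves the read-out beyond the scatter: (hydroxycarbamoyl)methyl in place of the group of 8 heavy atoms gives a 16-fold lower number from compound 2 to compound 4 (1.20 log units; beyond the scatter). The earlier compounds shown here offered no step of this kind, as none of them differ in one place. Nothing measured here bears on why the number falls.

Open, as far as these compounds go, is whether a longer chain or a chain carrying an amine at this position would restore the higher number. Also open, from the compounds shown here alone, is whether the step holds on the core of compound 1.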